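Trimethoxyphenyl substitution on the imidazolone aryl of the chalcone series

The source may report more compounds than this note shows. Statements on the series, on what has been measured and on what is new or still open speak of the compounds shown alone.

Measured compounds in a functional assay on SF-295 cells (Homo sapiens) for inhibition; on this read-out higher numbers stand for weaker inhibition of growth and lower numbers for stronger inhibition of growth:
- compound 1, `COc1cc(/C=C/C(=O)c2cccc(-n3cc(-c4ccccc4)[nH]c3=O)c2)ccc1O`, 3040 nM
- compound 2, `COc1ccc(-c2cn(-c3cccc(C(=O)/C=C/c4cc(OC)c(OC)c(OC)c4)c3)c(=O)[nH]2)cc1`, 4950 nM
- compound 3, `COc1ccc(-c2cn(-c3cccc(C(=O)/C=C/c4ccc(O)c(OC)c4)c3)c(=O)[nH]2)cc1`, 13900 nM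

Compound 2 stands second highest of the three numbers; its gap to compound 1 lies within the scatter, while compound 3 sits clearly higher, as a 2.8-fold higher number from compound 2 to compound 3 (0.45 log units; beyond the scatter) shows. Compound 4, `COc1cc(/C=C/C(=O)c2cccc(-n3cc(-c4cc(OC)c(OC)c(OC)c4)[nH]c3=O)c2)cc(OC)c1OC`, differs from compound 2 by 3,4,5-trimethoxyphenyl in place of 4-methoxyphenyl on an aromatic carbon.

Among the compounds with values here, no measured step changes the same aryl in the same way. Within the data shown here, the nearest precedent is a 4.6-fold higher number from compound 1 to compound 3 (0.66 log units; beyond the scatter), where a methoxy added on that aryl raised the number. The other step, a 2.8-fold higher number from compound 2 to compound 3 (0.45 log units; beyond the scatter), concerns the chain aryl and does not bear directly. A modest rise in this assay is therefore expected for compound 4, that is a 1.8-fold higher number from compound 2 to compound 4 (0.26 log units; within the scatter), with a wide range.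

Compound 4 is estimated at 9000 nM, between 3500 nM and 25000 nM.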

Compound 4, concentration for 50% growth inhibition: 4960 nM
Compound 4: the middle estimate sits 1.8-fold (0.26 log units) above what was measured, within the range that was stated.
By their numbers in this assay, from the lowest: compounds 1, 2 and 4 (each within the scatter of the next); then compound 3.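

In this assay, 3,4,5-trimethoxyphenyl in place of 4-methoxyphenyl on this aromatic carbon gives a 1.0-fold higher number from compound 2 to compound 4 (0.00 log units; within the scatter), so this larger aryl leaves the number within the scatter when the chain carries 3,4,5-trimethoxyphenyl. The rise seen with a methoxy added on this aryl, a 4.6-fold higher number from compound 1 to compound 3 (0.66 log units; beyond the scatter), does not recur here, although that step has a different chain aryl. Nothing in the data offers an explanation for this result.

Still open, from the compounds shown here alone, is how an amine or a carboxylic acid on this aryl would read in this assay. Also open, going by these compounds, is whether the 3,4,5-trimethoxyphenyl change behaves the same with the 4-hydroxy-3-methoxyphenyl chain aryl.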